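The source may hold more compounds than are shown below. What is called first, only, known or untested is meant among the compounds shown, and "the series" means these compounds.

Measured so far: compound 1 `Cc1cc(OCCCCCCC[N+]2(C)CCCCC2)cc(-n2cc(C(=O)Nc3cc(F)cc(F)c3)c(=O)c3ccc(N(C)C)nc32)c1`, 46.8%; compound 2 `Cc1cc(OCCCCCCC[n+]2ccccc2)cc(-n2cc(C(=O)Nc3cc(F)cc(F)c3)c(=O)c3ccc(N(C)C)nc32)c1`, 7.7%; compound 3 `Cc1cc(OCCCCCCC[N+]2(C)CCN(C)CC2)cc(-n2cc(C(=O)Nc3cc(F)cc(F)c3)c(=O)c3ccc(N(C)C)nc32)c1`, 2.8%, all in an assay on LX2 cells for inhibition of COL1A1 promoter (Homo sapiens), read by a luciferase reporter, with a stated time of 24 h, tested at 20 uM; on this read-out lower numbers stand for a weaker effect and higher numbers for a stronger effect at the one concentration tested.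

Compound 3 stands lowest of the three. Its nearest neighbour is compound 2, which sits within the scatter of it; compound 1 lies far above it, as the step of a number 44 percentage points lower from compound 1 to compound 3 (beyond the scatter) shows. Compound 4 `CC[N+]1(CCCCCCCOc2cc(C)cc(-n3cc(C(=O)Nc4cc(F)cc(F)c4)c(=O)c4ccc(N(C)C)nc43)c2)CCCC1` arises from compound 3 by a group of 7 heavy atoms (6 carbon, 1 nitrogen; one five-membered non-aromatic ring with 1 hetero atom) in place of a group of 8 heavy atoms (6 carbon, 2 nitrogen; one six-membered non-aromatic ring with 2 hetero atoms), on a saturated chain carbon, seven bonds along the chain from an oxygen on an aromatic ring. Within the data shown here, the steps that bear on this are a number 44 percentage points lower from compound 1 to compound 3 (beyond the scatter) and a number 39.1 percentage points lower from compound 1 to compound 2 (beyond the scatter), both large, and the small step of a number 4.9 percentage points lower from compound 2 to compound 3 (within the scatter). Because of a number 44 percentage points lower from compound 1 to compound 3 (beyond the scatter), a single-nitrogen non-aromatic ring such as compound 1 carries goes with a stronger effect than the two-nitrogen ring of compound 3, so a step up is expected: a number 32.2 percentage points higher from compound 3 to compound 4 (beyond the scatter). The estimate for compound 4 is 35%, between 10% and 60%.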

Compound 4, a percentage reported as inhibition, at one concentration (the size of the read-out at that concentration, not a potency): 35.1%
Beside the measured number, compound 4's estimate is 0.1 percentage points below it; measured number inside the range.
By their numbers in this assay, from the lowest: compounds 3 and 2 (each within the scatter of the next); then compound 4; then compound 1.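

Among these compounds, the position tolerates more than the one ring of compound 1: the five-membered non-aromatic ring with 1 hetero atom of compound 4 keeps much of the effect in this assay (a number 32.3 percentage points higher from compound 3 to compound 4 (beyond the scatter); a number 27.4 percentage points higher from compound 2 to compound 4 (beyond the scatter)). It still falls short of the six-membered ring (a number 11.7 percentage points lower from compound 1 to compound 4 (beyond the scatter)), although that step also exchanges the methyl on the ring nitrogen for an ethyl. No measurement shown gives a reason for these differences.

The compounds shown do not separate ring size from the ethyl group, which a five-membered ring bearing a methyl would address. On these data alone, how a morpholine ring or a longer chain would read at this position also remains open.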